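Cytotoxicity of three chromone amides and an expected fourth

The compounds below may be only part of what the source reports. "The series", "measured", "known", "first", "only" and "open" are said of these compounds alone.

In an ADME assay on HepG2 2.2.15 cells (Homo sapiens) for cytotoxicity, read by MTT assay, with stated times of 48 h and 9 days (a lower number here means that less compound is tolerated, a higher number that more compound is tolerated), compound 3 `COc1ccc2c(=O)c(/C=C/C(=O)NCc3ccc(F)cc3)coc2c1` gives 133000 nM, the lowest of the three numbers seen so far. Compound 2 `COc1ccc2c(=O)c(/C=C/C(=O)Nc3ccccc3)coc2c1` gives 523000 nM and compound 1 `COc1ccc2c(=O)c(/C=C/C(=O)Nc3cccc(Cl)c3)coc2c1` gives 1100000 nM in this assay. Compound 4 `COc1ccc2c(=O)c(/C=C/C(=O)Nc3ccccc3OC)coc2c1` differs from compound 3 by 2-methoxyphenyl in place of 4-fluorobenzyl on an amide-type nitrogen. Among the measured compounds shown here, the steps that bear on this are a 3.9-fold lower number from compound 2 to compound 3 (0.59 log units; beyond the scatter) and an 8.3-fold lower number from compound 1 to compound 3 (0.92 log units; beyond the scatter): both times an aryl group on the amide nitrogen tolerated more compound than the 4-fluorobenzyl group did. Compound 4 again carries an aryl group there, so in this assay a higher number is expected for it, of roughly a 3.8-fold higher number from compound 3 to compound 4 (0.58 log units; beyond the scatter). The estimate for compound 4 in this assay is 500000 nM, within a range from 200000 nM to 1300000 nM.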

Compound 4, half-maximal cytotoxic concentration: 1050000 nM
The estimate for compound 4 lay 2.1-fold (0.32 log units) below the measured number; the range from low to high includes it.
By their numbers in this assay, from the lowest: compound 3; then compounds 2, 4 and 1 (each within the scatter of the next, the first and the last beyond it).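

Compound 4 is a third aryl group on the amide-type nitrogen, and 2-methoxyphenyl in place of 4-fluorobenzyl gives the same direction as before (a 7.9-fold higher number from compound 3 to compound 4 (0.90 log units; beyond the scatter)) in this assay. Methoxy in place of hydrogen on an aromatic carbon makes no clear difference (a 2.0-fold higher number from compound 2 to compound 4 (0.30 log units; within the scatter)), and neither does 2-methoxyphenyl in place of 3-chlorophenyl (a 1.0-fold lower number from compound 1 to compound 4 (0.02 log units; within the scatter)), so these aryl groups cannot be told apart here. Nothing shown explains the aryl-benzyl gap. Still open, going by these compounds, is whether plain benzyl, a longer chain or an aminophenyl group on that nitrogen would follow the same pattern.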